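The source may hold more compounds than are shown below. What is called first, only, known or untested is meant among the compounds shown, and "the series" means these compounds.

Compound 3 `CCN(c1ccc(C#N)c(Cl)c1)c1cc(-c2c[nH]nc2C)ccc1C` gives 9030 nM in a functional assay on PC-3 cells (Homo sapiens) for antiproliferative activity, read by CCK-8 assay, with a stated time of 6 days (on this read-out higher numbers stand for weaker inhibition and lower numbers for stronger inhibition), the lowest of the two numbers available, though its gap to compound 2 lies within the scatter. Compound 2 `CCN(c1ccc(C#N)c(Cl)c1)c1cc(-n2cccn2)ccc1C` gives 15700 nM, and the step of a 1.7-fold lower number from compound 2 to compound 3 (0.24 log units; within the scatter) is too small to count as a real change. For compound 1 `CCN(c1ccc(C#N)c(Cl)c1)c1cc(-c2ccco2)ccc1C` the result is only a limit, > 30000 nM. From there, the steps of an at least 1.9-fold lower number from compound 1 to compound 2 (0.28 log units; that floor lies within the scatter) and an at least 3.3-fold lower number from compound 1 to compound 3 (0.52 log units; beyond the scatter) show that exchanging one small aromatic ring for another moves the number only modestly. Compound 4 `CCN(c1ccc(C#N)c(Cl)c1)c1cc(-c2ccncc2)ccc1C` differs from compound 3 by pyridin-4-yl in place of 3-methyl-1H-pyrazol-4-yl on an aromatic carbon. Within the data shown here, no measured step covers pyridin-4-yl, so the expected step of a 1.4-fold higher number from compound 3 to compound 4 (0.16 log units; within the scatter) is small, with a slight lean toward a higher number. Compound 4 is therefore estimated at 13000 nM, between 4000 nM and 40000 nM.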

Compound 4, half-maximal inhibitory concentration: 3580 nM
Compound 4: middle estimate off by 3.6-fold (0.56 log units), on the high side; measured number below the stated range.
By their numbers in this assay, from the lowest: compound 4; then compounds 3 and 2 (each within the scatter of the next). At a limit, above all of these: compound 1.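

In this assay, among these compounds, pyridin-4-yl, a six-membered aromatic ring, gives a 2.5-fold lower number from compound 3 to compound 4 (0.40 log units; beyond the scatter) and a 4.4-fold lower number from compound 2 to compound 4 (0.64 log units; beyond the scatter), the first steps at this position between two exact values that lie beyond the scatter. The entering group has no hydrogen-bond donor, so among these compounds a donor on this ring is not needed for the lowest number. Read against a limit, an at least 8.3-fold lower number from compound 1 to compound 4 (0.92 log units; beyond the scatter) is only a floor: the limit of > 30000 nM in this assay, at which 1 of the 4 values shown sits.

Still open, going by these compounds, is whether the ring nitrogen is needed at all, which a plain phenyl ring would show. Also open, on these data alone, is how pyridin-3-yl or an aminopyridine would behave here.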